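The source may hold more compounds than are shown below. What is called first, only, known or untested is meant among the compounds shown, and "the series" means these compounds.

Measured so far, in a functional assay on the whole organism (strain Kunming) with Mus musculus as the target, with a stated time of 0.5 h; on this read-out higher numbers stand for an effect only at larger amounts of compound and lower numbers for an effect already at smaller amounts:
compound 1 `O=C1NC2(CC2c2ccc3cccc(OCc4ccccc4)c3n2)C(=O)N1C1CCCCC1`, where compound 1 gives 300 mg/kg
compound 2 `O=C1NC2(CC2c2ccc3cccc(OCc4ccccc4)c3n2)C(=O)N1Cc1ccccc1`, where compound 2 gives 300 mg/kg

Compound 2 stands level with compound 1 on these numbers: the step of no change at the digits printed from compound 1 to compound 2 (within the scatter) shows no change beyond the scatter when the cyclohexyl is swapped for a benzyl on the amide-type nitrogen in the ring. Compound 3 `COc1ccc(N2C(=O)NC3(CC3c3ccc4cccc(OCc5ccccc5)c4n3)C2=O)cc1` keeps the shared core of compound 2 and changes only that same nitrogen substituent: 4-methoxyphenyl in place of benzyl on an amide-type nitrogen in a ring.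

For the measured compounds named here, the one measured step that touches this position is the step from compound 1 to compound 2, and it was flat. Going by the values given here, nothing here tells how a 4-methoxyphenyl on that nitrogen behaves, so the only guide is that one flat step. The expectation for no change at the digits printed from compound 2 to compound 3 (within the scatter) is therefore no movement beyond the scatter in this assay, in either direction. From the compounds shown here alone, on that basis compound 3 is estimated at 300 mg/kg in this assay, with a range from 150 mg/kg to 600 mg/kg, the width reflecting that this substituent is untested here.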

Compound 3, minimum effective dose: 300 mg/kg
The estimate for compound 3 equals the measured number at the digits printed, and the stated range covers the measured number.
By their numbers in this assay, from the lowest: compounds 1, 2 and 3 (each within the scatter of the next).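

In this assay, putting 4-methoxyphenyl in place of benzyl on the amide-type nitrogen gives no change at the digits printed from compound 2 to compound 3 (within the scatter), and putting it in place of cyclohexyl gives no change at the digits printed from compound 1 to compound 3 (within the scatter). The earlier pair showed only that two substituents made of carbon and hydrogen read alike at this nitrogen; the new group adds one oxygen and one hydrogen-bond acceptor, and the reading still stays level, so three different substituents now sit together within the scatter. Nothing available explains why this position stays flat across these three groups.

The compounds shown include no substituent on this nitrogen that moves the minimum effective dose in either direction, so it remains open whether an amine, a carboxylic acid or a longer chain ending in either group would do so. They also vary only this one nitrogen, which leaves open how the dose would respond to changes elsewhere on the shared core.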